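Ring-nitrogen chains in a series that stays at the limit

The compounds below may be only part of what the source reports. "The series", "measured", "known", "first", "only" and "open" are said of these compounds alone.

Three compounds sharing one core and differing only at a ring nitrogen have been read in a functional assay for antagonist activity at 5-hydroxytryptamine receptor 4 (Cavia porcellus); a higher number here means a more potent compound, by a factor of ten per unit of this negative logarithm, a lower number a less potent compound. Compound 1 `CN1CCN(CCNC(=O)n2c(=O)n(Cc3ccccc3)c3ccccc32)CC1` carries benzyl at that nitrogen; in this assay compound 1 is reported only as the limit < 6. Compound 2 `C=CCn1c(=O)n(C(=O)NCCN2CCN(C)CC2)c2ccccc21` carries allyl there; compound 2 likewise gives no number but the limit < 6. Compound 3 `CN1CCN(CCNC(=O)n2c(=O)[nH]c3ccccc32)CC1` carries hydrogen at the same nitrogen; compound 3 also stops at the limit < 6. All three values rest at a single point, (the limit of < 6 in this assay, at which 3 of the 3 values shown sit), and so none of the steps among them can be sized: a step that the two limits leave unreadable from compound 1 to compound 2, a step that the two limits leave unreadable from compound 1 to compound 3 and a step that the two limits leave unreadable from compound 2 to compound 3 are each unreadable. Compound 3 therefore stands at the limit, with no measured neighbour above or below it.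

Compound 4 `CCCn1c(=O)n(C(=O)NCCN2CCN(C)CC2)c2ccccc21` differs from compound 3 by propyl in place of hydrogen on an aromatic nitrogen. Among the measured compounds shown here, the steps that bear on this exchange are the two that also swap hydrogen for a carbon chain at that nitrogen, a step that the two limits leave unreadable from compound 1 to compound 3 and a step that the two limits leave unreadable from compound 2 to compound 3, and both are unreadable. No direction can be drawn from them; a step from compound 3 to compound 4 of about a step that the limit leaves unreadable from compound 3 to compound 4 is expected, most likely again ending in a limit. Compound 4 is estimated at 5.5, within 4.5 to 6.3.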

Compound 4, negative logarithm of the antagonist equilibrium constant: < 6
Compound 4 was reported as a limit (the forecaster's own chance of this, stated with the estimate: 75%); the middle value does not contradict the limit.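

In this assay compound 4 gives only a limit, < 6. Among the compounds shown here, the steps to compound 4 from compound 1, compound 2 and compound 3 cannot be read, so no new step is gained. Left open is whether any group on this aromatic nitrogen changes potency at all, as every value shown rests at one point: the limit of < 6 in this assay, at which 4 of the 4 values shown sit.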